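The source may report more compounds than this note shows. Statements on the series, on what has been measured and on what is new or still open speak of the compounds shown alone.

Measured compounds, all in a functional assay on HT-29 cells (Homo sapiens) for cytotoxicity, read by MTT assay, with a stated time of 24 h, tested at 0.64 ug/mL; on this read-out lower numbers stand for a weaker effect and higher numbers for a stronger effect at the one concentration tested:

Compound 1, `CN1CCN(CC(=O)Nc2ccc(-c3nc(-c4ccccc4)c(-c4ccccc4)n3C)cc2)CC1`, gives 18.8%.
Compound 2, `CCN1CCN(CC(=O)Nc2ccc(-c3nc(-c4ccccc4)c(-c4ccccc4)n3C)cc2)CC1`, gives 7.4%.
Compound 3, `Cn1c(-c2ccc(NC(=O)CN3CCN(Cc4ccccc4)CC3)cc2)nc(-c2ccccc2)c1-c1ccccc1`, gives 15.5%.

The three share one core and differ only in the group on the ring amine nitrogen at the end of the chain. Compound 3 stands second highest of the three numbers; its nearest neighbour is compound 1 (a number 3.3 percentage points lower from compound 1 to compound 3 (within the scatter)) and its furthest is compound 2 (a number 8.1 percentage points higher from compound 2 to compound 3 (within the scatter)), so compound 3 is not separated from either by more than the usual scatter. Within the data shown here, the one step that does stand out is a number 11.4 percentage points lower from compound 1 to compound 2 (beyond the scatter), a modest loss.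

Compound 4, `Cc1ccc(CN2CCN(CC(=O)Nc3ccc(-c4nc(-c5ccccc5)c(-c5ccccc5)n4C)cc3)CC2)cc1`, is the unmeasured one. Its difference from compound 3 is methyl in place of hydrogen on an aromatic carbon. Among the measured compounds shown here, no measured step changes this aromatic ring; every step so far swaps the whole group on the amine nitrogen, so none of them bears directly on this change. With compound 3 at 15.5% and the two steps that touch it lying within the scatter, the expectation for compound 4 is a step of no more than the scatter, a number 1.5 percentage points lower from compound 3 to compound 4 (within the scatter). Compound 4 is therefore estimated at 14%, with a range from 4% to 26%.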

Compound 4, a percentage reported as activity, at one concentration (the size of the read-out at that concentration, not a potency): 15.4%
For compound 4 the middle estimate is 1.4 percentage points below the measured one; measured number inside the range.
By their numbers in this assay, from the lowest: compounds 2, 4, 3 and 1 (each within the scatter of the next, the first and the last beyond it).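

In this assay the methyl on the aromatic carbon, para to a large group, turns benzyl into 4-methylbenzyl, and the result is a number 0.1 percentage points lower from compound 3 to compound 4 (within the scatter). Among these compounds, this is the first measured change made on that ring rather than to the whole group on the ring amine nitrogen, and at this position the methyl leaves the reading within the scatter. The new end group also stays close to the smaller ones, with a number 8 percentage points higher from compound 2 to compound 4 (within the scatter) and a number 3.4 percentage points lower from compound 1 to compound 4 (within the scatter), so compound 4 is not separated from any of the other three compounds, and no measurement shown here bears on what lies behind this result.

As far as these compounds go, whether a chlorine atom, a methoxy group or a carboxylic acid on this same aromatic carbon would shift the reading beyond the scatter stays open, as does the effect of a longer chain in place of the methyl. All four readings also come from a single concentration, so they show the size of the effect at that concentration only and leave open how the compounds would compare at other concentrations.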